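The source may hold more compounds than are shown below. What is called first, only, known or untested is meant among the compounds shown, and "the series" means these compounds.

Of the compounds shown here, two that share a common core have been measured in a functional assay on HT-1080 cells (Homo sapiens) for antiproliferative activity, read by sulforhodamine B assay, with a stated time of 48 h; a lower number here means a stronger inhibitor, a higher number a weaker inhibitor. Compound 1 `O=C(Nc1ccccc1)Nc1ccc(S(=O)(=O)Nc2ccnc3cc(C(F)(F)F)ccc23)cc1` carries a urea-linked phenyl on one end of a sulfonamide, and in this assay compound 1 gives 25400 nM. Compound 2 `CC(=O)NS(=O)(=O)c1ccc(N/C(S)=N\c2ccnc3cc(C(F)(F)F)ccc23)cc1` replaces that urea with a thiourea link and puts an acetyl group on the sulfonamide nitrogen; in this assay compound 2 gives 28300 nM. Of the two numbers, the value of compound 2 sits alongside that of compound 1, and the small gap between them falls within the usual scatter of repeated measurements, so the two compounds cannot be told apart on these data.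

Compound 3 `Cc1cc(NS(=O)(=O)c2ccc(N/C(S)=N\c3ccnc4cc(C(F)(F)F)ccc34)cc2)on1` keeps the core of compound 2 and changes only one spot: 3-methyl-1,2-oxazol-5-yl in place of acetyl on a sulfonamide nitrogen. Among the measured compounds shown here, no measured pair shows what such a change does here, so nothing in the data points in a clear direction. The expected step in this assay, a 1.4-fold lower number from compound 2 to compound 3 (0.15 log units; within the scatter), is therefore taken as small and within the scatter. Compound 3 is expected to give about 20000 nM, with a plausible range from 6000 nM to 60000 nM.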

Compound 3, half-maximal inhibitory concentration: 27300 nM
Compound 3: the middle estimate sits 1.4-fold (0.14 log units) below what was measured; low and high end bracket the measured number.
By their numbers in this assay, from the lowest: compounds 1, 3 and 2 (each within the scatter of the next).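

Among the compounds shown here, compound 2 and compound 3 form the first pair here that differs in only one place, so the effect of a single change on a sulfonamide nitrogen can now be read directly. Replacing acetyl with 3-methyl-1,2-oxazol-5-yl gives a step of a 1.0-fold lower number from compound 2 to compound 3 (0.02 log units; within the scatter) in this assay, which lies within the scatter even though an open group of 3 heavy atoms gives way to a five-membered aromatic ring group of 6 heavy atoms. This one pair therefore shows that the two groups cannot be told apart at this position in this assay, although no information is available to explain that result.

The compounds shown leave open whether any other group on this sulfonamide nitrogen, such as a carboxylic acid, an amine or a longer alkyl chain, would produce a step beyond the scatter. On these data alone, it also remains open what the thiourea link contributes by itself, and whether a change at another part of the shared core would have a larger effect on the number.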